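Amide-side swap on a bis-sulfonyl piperidine series

The compounds below may be only part of what the source reports. "The series", "measured", "known", "first", "only" and "open" are said of these compounds alone.

Of the compounds shown here, three have been measured in a functional assay on MIA PaCa-2 cells (Homo sapiens) for inhibition, read by MTT assay, with a stated time of 7 days; a lower number here means a stronger inhibitor, a higher number a weaker inhibitor. Compound 1 `O=C([C@@H]1CCCN(S(=O)(=O)c2ccc(S(=O)(=O)N3CC[C@@H](O)C3)cc2)C1)N1CCC(F)(F)CC1` gives 210 nM, compound 2 `CCN(CC)S(=O)(=O)c1ccc(S(=O)(=O)N2CCC[C@@H](C(=O)N3CCC(C(F)(F)F)CC3)C2)cc1` gives 320 nM, and compound 3 `CC(C)S(=O)(=O)c1ccc(S(=O)(=O)N2CCC[C@@H](C(=O)N3CCC(F)(F)CC3)C2)cc1` gives 11 nM. Compound 2 thus has the highest number of the three; its value and that of compound 1 lie within the scatter of each other, while compound 3 sits far below both. Among the compounds with values here, the only single-point step known, a 19-fold lower number from compound 1 to compound 3 (1.28 log units; beyond the scatter), concerns the sulfonyl side of the shared core and is large.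

Compound 4 `CCN(CC)S(=O)(=O)c1ccc(S(=O)(=O)N2CCC[C@@H](C(=O)N3CC[C@H](OC)C3)C2)cc1` differs from compound 2 on the other side: 3-methoxypyrrolidin-1-yl in place of 4-(trifluoromethyl)piperidin-1-yl on a carbonyl carbon. Within the data shown here, no measured step touches this carbonyl position, so the known data offer no direct guide to its size or direction. Compound 1 and compound 2, which differ at both ends, show no difference beyond the scatter. The step of a 1.6-fold higher number from compound 2 to compound 4 (0.19 log units; within the scatter) is therefore expected to be modest and uncertain in direction. Compound 4 is estimated at 500 nM, with a range from 150 nM to 2000 nM.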

Compound 4, half-maximal inhibitory concentration: 2460 nM
Estimate against measurement, compound 4: 4.9-fold (0.69 log units) below; measured number outside the range, above it.
By their numbers in this assay, from the lowest: compound 3; then compounds 1 and 2 (each within the scatter of the next); then compound 4.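

In this assay, within the data shown here, the carbonyl position proves able to move the number on its own: a 7.7-fold higher number from compound 2 to compound 4 (0.89 log units; beyond the scatter), the first measured step at this place, lies beyond the scatter. Among these compounds, until now, the only single-place step had been on a sulfonyl sulfur, so the result shows that the amide side also matters, and that 3-methoxypyrrolidin-1-yl is the less favourable of the two groups on this scaffold. No supporting data bear on what lies behind the step. The change replaces a six-membered ring with a five-membered one and trifluoromethyl with methoxy together, so the compounds shown cannot separate the two. Going by these compounds, a 4-methoxypiperidin-1-yl group on the same carbonyl carbon would divide them, and it remains open whether the step would hold with the isopropyl group of compound 3.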